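The source may hold more compounds than are shown below. What is called first, only, known or untested is meant among the compounds shown, and "the series" means these compounds.

Compound 3 `N#Cc1cccc(C2=NC(c3ccc(F)cc3)(c3ccc(F)cc3)CN2)c1` gives 2.7 nM in an assay on LM cells for displacement of a labelled ligand from Neuropeptide Y receptor type 5 (Homo sapiens) (on this read-out higher numbers stand for weaker inhibition and lower numbers for stronger inhibition), the lowest number of the three compounds measured, though its steps to the others stay within the scatter: compound 2 `O=[N+]([O-])c1cccc(C2=NC(c3ccc(F)cc3)(c3ccc(F)cc3)CN2)c1` gives 4.3 nM and compound 1 `Fc1ccc(C2(c3ccc(F)cc3)CNC(c3cccc(Br)c3)=N2)cc1` gives 4.8 nM. The three steps, a 1.1-fold lower number from compound 1 to compound 2 (0.05 log units; within the scatter), a 1.8-fold lower number from compound 1 to compound 3 (0.25 log units; within the scatter) and a 1.6-fold lower number from compound 2 to compound 3 (0.20 log units; within the scatter), all fall within the scatter, so bromo, nitro and cyano on the aromatic carbon of this ring are indistinguishable on this read-out.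

Compound 4 `Cc1cccc(C2=NC(c3ccc(F)cc3)(c3ccc(F)cc3)CN2)c1` carries the change (methyl in place of cyano on an aromatic carbon). Among the measured compounds shown here, no measured step exchanges a cyano for a methyl, so the comparison rests only on the three substituent swaps at the same place, each of which left the number where it was. The expectation for compound 4 is therefore a step of a 1.5-fold higher number from compound 3 to compound 4 (0.17 log units; within the scatter), no larger than the scatter, in this assay. Compound 4 is estimated at 4 nM, with a range from 1.5 nM to 12 nM.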

Compound 4, half-maximal inhibitory concentration: 30 nM
Beside the measured number, compound 4's estimate is 7.5-fold (0.88 log units) below it; measured number outside the range, above it.
By their numbers in this assay, from the lowest: compounds 3, 2 and 1 (each within the scatter of the next); then compound 4.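

In this assay this place on the ring proves sensitive to its substituent after all: methyl is the first group shown to move the number beyond the scatter, and it does so against all three earlier groups (an 11-fold higher number from compound 3 to compound 4 (1.05 log units; beyond the scatter); a 7.0-fold higher number from compound 2 to compound 4 (0.84 log units; beyond the scatter); a 6.3-fold higher number from compound 1 to compound 4 (0.80 log units; beyond the scatter)). Cyano, nitro and bromo remain within the scatter of one another, so the result sets methyl apart from all three and is not specific to the loss of the nitrile. No measurement available here bears on why methyl differs from these groups.

The compounds shown leave open whether an amine, a methoxy group or a carboxylic acid at this place would fall with cyano, nitro and bromo or with methyl. They also leave open whether a longer chain such as ethyl would give a number higher still.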